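The source may report more compounds than this note shows. Statements on the series, on what has been measured and on what is new or still open speak of the compounds shown alone.

Measured so far:
compound 1, `O=C(O)CCc1ccc(NCc2cccc(Br)c2)cc1`: 794 nM
compound 2, `O=C(O)CCc1ccc(NCc2ccccc2)cc1`: 7940 nM

In a functional assay for agonist activity at Free fatty acid receptor 1 (Homo sapiens) (a lower number here means that less compound is needed, a higher number that more compound is needed for the effect), compound 2 gives the highest number of the two measured, and its nearest neighbour is compound 1, whose number is a full step lower. Going by the values given here, the one measured step is a 10-fold higher number from compound 1 to compound 2 (1.00 log units; beyond the scatter). Compound 2 carries hydrogen where compound 1 carries bromo on an aromatic carbon, and compound 2 needs far more compound for the same effect.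

Compound 3, `NC(=O)c1cccc(CNc2ccc(CCC(=O)O)cc2)c1`, returns to that same position with a different group: carbamoyl in place of hydrogen on an aromatic carbon. Among the compounds with values here, only the step from compound 1 to compound 2 bears on this change, and it shows that a substituent on this aromatic carbon can matter well beyond the scatter. A carbamoyl is not a bromo, so the gain is expected to be smaller. Compound 3 is therefore expected to give a lower number than compound 2, estimated at 2500 nM (range 800 nM to 8000 nM), a step of a 3.2-fold lower number from compound 2 to compound 3 (0.50 log units; beyond the scatter).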

Compound 3, half-maximal effective concentration: < 31700 nM
Compound 3: only a limit was reported (the forecaster's own chance of this, stated with the estimate: 5%); the middle value lies beyond the limit too.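

For compound 3, this assay gives only a limit, < 31700 nM, not a number. The steps to it from compound 1 and compound 2 therefore cannot be read. From the compounds shown here alone, whether carbamoyl in place of hydrogen on an aromatic carbon lowers the number, raises it or leaves it unchanged stays open.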